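Compound 4: an ether-linked acid replaces the benzylamine

A few compounds are considered here, and "the series" means these few. Any claim that something is new, unique, unknown or untested is made for them only; others in the source may bear on it.

Compound 1, `CC(C)c1onc(-c2c(Cl)cccc2Cl)c1COc1ccc(NC(=O)c2ccc(C(=O)O)cc2)c(C(F)(F)F)n1`: 21%
Compound 2, `CC(C)c1onc(-c2c(Cl)cccc2Cl)c1COc1ccc(N(C)Cc2cccc(C(=O)O)c2)c(C(F)(F)F)n1`: 89%
Compound 3, `CN(Cc1cccc(C(=O)O)c1)c1ccc(OCc2c(-c3c(Cl)cccc3Cl)noc2C2CC2)nc1C(F)(F)F`: 79%

In a functional assay on HEK293 cells for agonist activity at Bile acid receptor (Homo sapiens) (on this read-out higher numbers stand for larger maximal responses and lower numbers for smaller maximal responses), compound 3 stands second highest of the three numbers; it lies within the usual scatter of compound 2, as a number 10 percentage points lower from compound 2 to compound 3 (within the scatter) shows, and far above compound 1. Compound 4, `O=C(O)c1ccccc1OCc1ccc(OCc2c(-c3c(Cl)cccc3Cl)noc2C2CC2)nc1C(F)(F)F`, has not been measured. It differs from compound 3 by (2-carboxyphenoxy)methyl in place of (3-carboxybenzyl)(methyl)amino on an aromatic carbon. Among the compounds with values here, the only measured step that touches the attachment of the carboxyphenyl group is a number 68 percentage points higher from compound 1 to compound 2 (beyond the scatter), which shows that such a change can move the result a great deal; a number 10 percentage points lower from compound 2 to compound 3 (within the scatter) is unrelated. Within the data shown here, no measured step tests an ether attachment or a 2-carboxyphenoxy group, so the direction is uncertain. Compound 4 is therefore expected to come in somewhat lower, the estimated step being a number 19 percentage points lower from compound 3 to compound 4 (beyond the scatter). The estimate for compound 4 is 60%, with a wide range from 20% to 95%.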

Compound 4, largest response reached (reported as efficacy), in percent of the reference or control that the assay uses: 63%
Compound 4: the middle estimate sits 3 percentage points below what was measured, and the stated range covers the measured number.
By their numbers in this assay, from the lowest: compound 1; then compound 4; then compounds 3 and 2 (each within the scatter of the next).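

With (2-carboxyphenoxy)methyl in place of (3-carboxybenzyl)(methyl)amino on this aromatic carbon, the result is a number 16 percentage points lower from compound 3 to compound 4 (beyond the scatter), a modest loss. The position therefore tolerates a group without the nitrogen, since compound 4 still gives 63% in this assay, but the exchange is not neutral as the earlier step at the cyclopropyl position was. No data on hand explain the drop. Going by these compounds, the linker and the place of the acid on the ring change together, so their separate shares remain open. Also open, on these data alone, is how a (3-carboxyphenoxy)methyl group, or a tetrazole replacing the carboxylic acid, would behave here.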